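Chloro in Place of Ethyl: Expected Outcome for Compound 4

This account rests on a few compounds, and the source may have more. Where it says the series, first, only, none or still open, it means among the compounds named here.

In a functional assay on the whole organism (strain Sprague-Dawley) for inhibition, with Rattus norvegicus as the target (on this read-out lower numbers stand for an effect already at smaller amounts and higher numbers for an effect only at larger amounts of compound), compound 2 `CCc1cccc2c(=O)c(-c3nn[nH]n3)c[nH]c12` gives 0.312 mg/kg, the only number among the three results shown. For compound 1 `O=c1c(-c2nn[nH]n2)c[nH]c2c(F)ccc(F)c12` the assay reports only a limit, > 0.156 mg/kg. For compound 3 `COc1ccc2cc(C(=O)O)cnc2c1` the assay likewise reports only a limit, > 25 mg/kg. Compound 4 `O=c1c(-c2nn[nH]n2)c[nH]c2c(Cl)cccc12` has not yet been tested in this assay; it differs from compound 2 by chloro in place of ethyl on an aromatic carbon. Going by the values given here, no measured pair differs in a single place, so no step size is known from these data. The entering chloro, like the leaving ethyl, carries no ring and no net charge, and the step is expected to stay within the usual scatter of this assay, in no particular direction. The estimated step is a 1.0-fold lower number from compound 2 to compound 4 (0.02 log units; within the scatter). Compound 4 is expected to give 0.3 mg/kg in this assay, within 0.1 mg/kg to 1 mg/kg.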

Compound 4, minimum effective dose: 0.078 mg/kg
For compound 4 the middle estimate is 3.8-fold (0.59 log units) above the measured one, and the stated range ends above it.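

Chloro in place of ethyl on this aromatic carbon gives a 4.0-fold lower number from compound 2 to compound 4 (0.60 log units; beyond the scatter) in this assay. Going by these compounds alone, this is the only single-place step, and it shows that the read-out responds to the group at this position, which the earlier compounds could not show. Nothing in the data shown accounts for the size or direction of this step.

As far as these compounds go, the finding rests on one pair, so it remains open whether it reflects the arrival of chloro or the loss of ethyl. A methyl, a nitrile or an amine on the same carbon would help separate the two.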